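The source may hold more compounds than are shown below. What is called first, only, known or untested is meant among the compounds shown, and "the series" means these compounds.

Measured compounds in an assay on isolated protein for inhibition of ubiquitin carboxyl-terminal hydrolase 7 (Homo sapiens), read by fluorescence, with stated times of 30 min and 1 h; on this read-out lower numbers stand for stronger inhibition and higher numbers for weaker inhibition:
- compound 1, `Cc1cc(Cl)cc(-c2ccnc3cc(CN4C(=O)CCC4=O)sc23)c1O[C@H]1C[C@H](N)C1`: 3.4 nM
- compound 2, `Cc1cc(Cl)cc(-c2ccnc3cc(CN4C(=O)C5C(C4=O)C5(C)C)sc23)c1NC1CCCNC1`: 0.78 nM
- compound 3, `O=C([C@H]1Cc2cc(Cl)cc(-c3ccnc4[nH]ccc34)c2O1)N1CCNCC1`: 450 nM

Compound 1 stands second highest of the three numbers in this assay. Its nearest neighbour is compound 2, whose number is lower by a margin beyond the usual scatter; furthest away is compound 3, whose number is higher by a gap well beyond the scatter. Compounds 1 and 2 share the same core with a saturated amine ring attached through the aromatic ring; compound 3 carries a different core and a different arrangement of the amine, and no single-change comparison to compound 1 exists for either.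

The unmeasured compound 4, `Cc1cc(Cl)cc(-c2ccnc3cc(CN4C(=O)CCC4=O)sc23)c1O[C@@H]1CCNC[C@@H]1C`, keeps the core of compound 1 and differs from it only in one place: 3-methylpiperidin-4-yl in place of 3-aminocyclobutyl on an oxygen on an aromatic ring. The donor and acceptor count of the leaving and entering groups is the same, and the basic amine is retained within a larger ring.

Given that compound 1 gives 3.4 nM and that the related compound 2 with a six-membered amine ring gives 0.78 nM, no large movement is expected; the step from compound 1 to compound 4 is estimated at a 1.4-fold lower number from compound 1 to compound 4 (0.13 log units; within the scatter), slightly toward stronger inhibition but within or near the scatter. Compound 4 is expected to give about 2.5 nM, with a range of 0.8 nM to 8 nM.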

Compound 4, half-maximal inhibitory concentration: 2.1 nM
For compound 4 the middle estimate is 1.2-fold (0.08 log units) above the measured one; measured number inside the range.
By their numbers in this assay, from the lowest: compound 2; then compounds 4 and 1 (each within the scatter of the next); then compound 3.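

In this assay, 3-methylpiperidin-4-yl in place of 3-aminocyclobutyl on an oxygen on an aromatic ring gives a 1.6-fold lower number from compound 1 to compound 4 (0.21 log units; within the scatter), so on the shared core this position accepts either group with no change that can be told from the scatter. The earlier compounds shown here offered no comparison in one place, whereas this pair shows that a six-membered non-aromatic ring with its nitrogen in the ring reads the same as a four-membered carbon ring carrying an amine, despite the larger group and the different placing of the nitrogen. No measured property is at hand to explain why the two groups read alike.

The compounds shown leave open what the methyl and the two defined stereocentres each contribute, since the step changes ring size, nitrogen placing and methyl together. Going by these compounds, how a plain piperidin-4-yl, the other stereoisomers of the 3-methylpiperidin-4-yl group, or an open-chain aminoethyl group would read on this oxygen remains open, and so does the limit of what this position accepts.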